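Propargylamine Coumarin Ethers: Varying the Benzyl Aryl Group

The compounds below may be only part of what the source reports. "The series", "measured", "known", "first", "only" and "open" are said of these compounds alone.

Compound 2 `C#CCN(CCCOc1ccc2ccc(=O)oc2c1)Cc1ccc(C(C)C)cc1` is one of two coumarin propargylamines characterised in an assay on isolated protein for inhibition of Amine oxidase [flavin-containing] B (Homo sapiens), read by fluorescence and Amplex Red, with stated times of 15 min and 20 min; on this read-out higher numbers stand for weaker inhibition and lower numbers for stronger inhibition. Its partner, compound 1 `C#CCN(CCCOc1ccc2ccc(=O)oc2c1)Cc1ccc(OC)cc1`, carries a methoxy on the aromatic ring of the benzyl group. In this assay compound 1 gives 6080 nM, and compound 2 gives 7580 nM. For the measured compounds named here, the step of a 1.2-fold higher number from compound 1 to compound 2 (0.10 log units; within the scatter) is the only measured step in the set, and it does not rise above the scatter; compound 2 therefore holds the higher of the two numbers, but by a margin that cannot be read as a real difference.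

Compound 3 `C#CCN(CCCOc1ccc2ccc(=O)oc2c1)Cc1cccc(F)c1` is not yet measured. It differs from compound 2 in that (3-fluorophenyl in place of 4-isopropylphenyl on a saturated chain carbon bound to an amine nitrogen). Going by the values given here, the single measured step, from compound 1 to compound 2, exchanged one substituent on the benzyl aromatic ring for another and moved the number only within the scatter. On that basis compound 3 is expected to change little in this assay, with a step of a 1.4-fold lower number from compound 2 to compound 3 (0.14 log units; within the scatter) that most likely stays inside the scatter. Compound 3 is estimated to give 5500 nM, within a range from 2000 nM to 15000 nM.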

Compound 3, half-maximal inhibitory concentration: 4440 nM
Estimate against measurement, compound 3: 1.2-fold (0.09 log units) above; the range from low to high includes it.
By their numbers in this assay, from the lowest: compounds 3, 1 and 2 (each within the scatter of the next).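

In this assay, placing 3-fluorophenyl on a saturated chain carbon bound to an amine nitrogen in place of 4-isopropylphenyl gives a 1.7-fold lower number from compound 2 to compound 3 (0.23 log units; within the scatter) and in place of 4-methoxyphenyl gives a 1.4-fold lower number from compound 1 to compound 3 (0.14 log units; within the scatter) in the same series. The earlier pair differed only in the group carried at the 4-position of the phenyl ring, whereas compound 3 has a fluorine at the 3-position and a smaller group, with 7 heavy atoms against the 9 of 4-isopropylphenyl, and all three compounds still stand within the scatter of one another. No measurement is available that would explain why these numbers stay together.

The compounds shown leave open whether the placement of the fluorine matters, which 4-fluorophenyl would test directly against compound 3. They also leave open whether any group at this position can move the number beyond the scatter, for example a phenyl ring carrying a carboxylic acid or an amine, or whether a longer chain between the amine nitrogen and the aromatic ring would do so.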